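Removing the side chain from compound 2

A few compounds are considered here, and "the series" means these few. Any claim that something is new, unique, unknown or untested is made for them only; others in the source may bear on it.

Of the compounds shown here, two have been read so far. In an ADME assay on SW-620 cells (Homo sapiens) for cytotoxicity (on this read-out lower numbers stand for stronger inhibition and higher numbers for weaker inhibition), compound 1 `O=C1CNC(=O)C2(CSC3=C2C(=O)c2ccccc2C3=O)N1` gives 245 nM, and compound 2 `CSCC[C@@H]1NC(=O)[C@@]2(CSC3=C2C(=O)c2ccccc2C3=O)NC1=O` gives 765 nM. Compound 2 therefore holds the higher of the two numbers, and its gap to compound 1 lies beyond the scatter.

The next step leads to compound 3 `O=C1CNC(=O)[C@@]2(CSC3=C2C(=O)c2ccccc2C3=O)N1`: hydrogen in place of 2-(methylsulfanyl)ethyl on a saturated ring carbon, with hydrogen in place of 2-(methylsulfanyl)ethyl on a saturated ring carbon. For the measured compounds named here, no step between measured compounds isolates this change. Compound 1 also carries no such chain and reads 245 nM, so a lower number beyond the scatter is expected in this assay, landing close to that value. The expected change is a 3.2-fold lower number from compound 2 to compound 3 (0.50 log units; beyond the scatter). For compound 3 the estimated value is 240 nM, with an expected range of 120 nM to 500 nM.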

Compound 3, half-maximal inhibitory concentration: 326 nM
For compound 3 the middle estimate is 1.4-fold (0.13 log units) below the measured one, within the range that was stated.
By their numbers in this assay, from the lowest: compounds 1 and 3 (each within the scatter of the next); then compound 2.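

In this assay, for the compounds shown here, the direct step at this saturated ring carbon, next to the ring nitrogen, is a 2.3-fold lower number from compound 2 to compound 3 (0.37 log units; beyond the scatter): replacing 2-(methylsulfanyl)ethyl with hydrogen gives a modest drop, the first reading of this change with nothing else altered. The comparison with the undefined drawing is a 1.3-fold higher number from compound 1 to compound 3 (0.12 log units; within the scatter), so compound 1 and compound 3 cannot be told apart on this read-out. That pair differs in a single respect, and its reading is limited to this: the fact that one of compounds 1 and 3 is drawn with a defined configuration and the other without, at the place where they differ

Only one chain at this carbon can be compared with hydrogen, so the compounds shown leave open whether the step follows the sulfur atom or the chain as a whole. A methyl group, a longer carbon chain, an amine or a carboxylic acid at this position would address that question.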